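Three Aryl Groups on a Shared Core, One Left to Measure

The source may hold more compounds than are shown below. What is called first, only, known or untested is meant among the compounds shown, and "the series" means these compounds.

The three measured compounds share a core in which a piperazine dithiocarbamate is linked to a triazole that carries an aryl group. Compound 1 `COc1ccc(Cn2cc(CSC(=S)N3CCN(C(=O)OCc4ccccc4)CC3)nn2)cc1` was tested in a functional assay on ECa-109 cells (Homo sapiens) for inhibition, read by MTT assay, with a stated time of 72 h (a lower number here means a stronger inhibitor, a higher number a weaker inhibitor), and gives 58300 nM. Compound 2 `Cc1ccc(-n2cc(CSC(=S)N3CCN(C(=O)OC(C)(C)C)CC3)nn2)cc1` gives 114000 nM in the same test, a value that sits within the usual scatter of the number for compound 1, so the two cannot be told apart. Compound 3 `Fc1ccccc1Cn1cc(CSC(=S)N2CCNCC2)nn1` reaches only a limit of the assay and gives > 128000 nM; the compound is thus recorded as a limit and not as a number (the limit of > 128000 nM in this assay, at which 1 of the 3 values shown sits).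

Compound 4 `COc1cc(Cn2cc(CSC(=S)N3CCN(C(=O)OCc4ccccc4)CC3)nn2)cc(OC)c1OC` has not been measured yet. It differs from compound 1 in one place: 3,4,5-trimethoxyphenyl in place of 4-methoxyphenyl on a saturated chain carbon bound to an aromatic nitrogen. In words, 3,4,5-trimethoxyphenyl in place of 4-methoxyphenyl on a saturated chain carbon bound to an aromatic nitrogen.

Within the data shown here, no measured pair in this set shows the effect of such a change, so the expectation rests on compound 1 alone. The step from compound 1 to compound 4 is expected to be a small one toward a lower number, possibly within the scatter, a 1.9-fold lower number from compound 1 to compound 4 (0.29 log units; within the scatter). Compound 4 is therefore estimated to give 30000 nM in this assay, with a range from 8000 nM to 120000 nM.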

Compound 4, half-maximal inhibitory concentration: > 128000 nM
Compound 4: no number, only a limit; the forecaster's own chance of this, stated with the estimate: 10%; middle value at least 4.2-fold (0.63 log units) from the limit.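

Among these compounds, the swap of 4-methoxyphenyl for 3,4,5-trimethoxyphenyl, on a saturated chain carbon bound to an aromatic nitrogen, is the first change in a single place that can be read in this assay, and the result is an at least 2.1-fold higher number from compound 1 to compound 4 (0.34 log units; beyond the scatter). This shows that the aryl group at this position is not a free spot in the shared core: adding methoxy groups to it moves the result toward the weaker side, by more than repeated measurements would scatter, and not toward the stronger side as the lone starting point of compound 1 might have suggested. The value of compound 4 is a limit and not a number, so the step gives only a minimum size, and the true distance from compound 1 stays unknown: the limit of > 128000 nM in this assay, at which 2 of the 4 values shown sit.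

A single pair cannot tell whether the outcome depends on how many methoxy groups the ring carries or on where they stand. It also leaves open how this ring would read with a different group in place of methoxy, such as a hydroxyl, an amine or a carboxylic acid.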